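The source may hold more compounds than are shown below. What is called first, only, known or untested is meant among the compounds shown, and "the series" means these compounds.

Series notes, compound 1 to compound 4.

Compound 1 `C=CC1=C(C(=O)NCc2ccc(C)cc2)C(c2ccc(F)cc2)OC1` is measured in a functional assay on A549 cells (Homo sapiens) for cytotoxicity, read by MTT assay, with a stated time of 24 h; a higher number here means a weaker inhibitor, a lower number a stronger inhibitor. In this assay compound 1 gives > 100000 nM, which is a limit of the assay and not a number. Compound 2 `C=CC1=C(C(=O)NCC(C)C)C(c2ccc(Cl)c(Cl)c2)OC1` gives > 100000 nM in this assay, again only a limit. Compound 3 `C=CC1=C(C(=O)Nc2ccccc2)C(c2ccc(OC)cc2)OC1` likewise gives > 100000 nM in this assay, a limit. Among the compounds with values here, compound 1 therefore stands where every value shown stands, at the limit of > 100000 nM in this assay, at which 3 of the 3 values shown sit; no measured pair differs in one place, so no step between measured compounds can be sized.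

Compound 4 `C=CC1=C(C(=O)Nc2cccc(C)c2)C(c2ccc(F)cc2)OC1` is not yet measured. It differs from compound 1 by 3-methylphenyl in place of 4-methylbenzyl on an amide-type nitrogen. With all three values shown sitting at the same limit, the step from compound 1 to compound 4 in this assay is expected to be none beyond the usual scatter, and the estimate for that step is a step that the limit leaves unreadable from compound 1 to compound 4. For compound 4 a value of about 150000 nM is expected in this assay, within 50000 nM to 500000 nM, most likely reported again as a limit rather than a number.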

Compound 4, half-maximal inhibitory concentration: > 100000 nM
Compound 4 ended at the assay's limit; the forecaster's own chance of this, stated with the estimate: 85%; the middle value lies beyond the limit too.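

Within the data shown here, compound 1 and compound 4 both sit at a limit in this assay, so no step between them can be read: the limit of > 100000 nM in this assay, at which 4 of the 4 values shown sit. The compounds shown leave open whether any change to the shared core gives a number rather than a limit in this assay for this series.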